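Carbonyl substituent change from compound 3 to compound 4

This account rests on a few compounds, and the source may have more. Where it says the series, first, only, none or still open, it means among the compounds named here.

Among the compounds with values here, compound 3 `Cc1nc(S(C)(=O)=O)ccc1Oc1ncnc(OC2CCN(C(=O)SC(C)(C)C)CC2)c1F` stands lowest of the three numbers measured so far in a functional assay on isolated protein for inhibition of Glucose-dependent insulinotropic receptor (Homo sapiens), read by HTRF and cAMP accumulation; on this read-out higher numbers stand for an effect only at larger amounts of compound and lower numbers for an effect already at smaller amounts: compound 3 gives 4.83 nM. Compound 1 `Cc1nc(S(C)(=O)=O)ccc1Oc1ncnc(OC2CCN(C(=O)OC(C)(C)CF)CC2)c1F` gives 19.9 nM and compound 2 `CCC1(OC(=O)N2CCC(Oc3ncnc(Oc4ccc(S(C)(=O)=O)nc4C)c3F)CC2)CC1` gives 22 nM. The steps into compound 3 are a 4.1-fold lower number from compound 1 to compound 3 (0.61 log units; beyond the scatter) and a 4.6-fold lower number from compound 2 to compound 3 (0.66 log units; beyond the scatter), both beyond the scatter, while a 1.1-fold higher number from compound 1 to compound 2 (0.04 log units; within the scatter) lies within it.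

Compound 4 `Cc1nc(S(C)(=O)=O)ccc1Oc1ncnc(OC2CCN(C(=O)C3(F)CCC3)CC2)c1F` changes compound 3 at the same carbonyl carbon: a group of 5 heavy atoms (4 carbon, 1 fluorine; one four-membered non-aromatic ring of carbon only) in place of a group of 5 heavy atoms (4 carbon, 1 sulfur; no ring), on a carbonyl carbon. The place is the carbonyl carbon whose other neighbours are an amide-type nitrogen in a ring. The two measured steps also exchange the group on that carbon, and that is all that ties them to this change. Within the data shown here, none of the measured compounds carries a four-membered ring or a fluorine there, so the direction is not fixed by them. They show that exchanging the group on the carbonyl carbon moves the number by a modest amount, and the two compounds without sulfur in that place sit at the higher numbers. A modest rise back toward those numbers is therefore expected for compound 4, though the uncertainty is wide, and the expected step is a 2.1-fold higher number from compound 3 to compound 4 (0.32 log units; beyond the scatter). For compound 4 the estimate in this assay is 10 nM, with a range of 3 nM to 35 nM.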

Compound 4, half-maximal effective concentration: 24.7 nM
The estimate for compound 4 lay 2.5-fold (0.39 log units) below the measured number, and the stated range covers the measured number.
By their numbers in this assay, from the lowest: compound 3; then compounds 1, 2 and 4 (each within the scatter of the next).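

In this assay, the change from the (tert-butyl)sulfanyl group to the fluorinated four-membered ring on the carbonyl carbon gives a clear loss against compound 3 (a 5.1-fold higher number from compound 3 to compound 4 (0.71 log units; beyond the scatter)). The new group instead falls in with those of the other two compounds (a 1.2-fold higher number from compound 1 to compound 4 (0.09 log units; within the scatter); a 1.1-fold higher number from compound 2 to compound 4 (0.05 log units; within the scatter)), so three groups that differ in ring size, in fluorine and in the presence of oxygen are not separated here, and among these four compounds only the sulfur-bearing group of compound 3 stands apart. The earlier compounds could not show this, since both steps into compound 3 started from oxygen-bearing groups, and no measurement shown accounts for the separation.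

Open, going by these compounds, is whether the sulfur atom itself sets compound 3 apart or the tert-butyl group with it, a question that tert-butoxy or tert-butylamino on the same carbonyl carbon would address. Also open, on these data alone, is what the fluorine contributes to compound 4, which plain cyclobutyl in that place would test.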